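Shrinking the Amide Nitrogen Substituent Toward Hydrogen

A few compounds are considered here, and "the series" means these few. Any claim that something is new, unique, unknown or untested is made for them only; others in the source may bear on it.

Compound 1, `COc1ccc2c(c1)OC(c1cc(OC)c(OC)c(OC)c1)C(C(=O)Nc1ccccc1)=C2`: 17500 nM
Compound 2, `CNC(=O)C1=Cc2ccc(OC)cc2OC1c1cc(OC)c(OC)c(OC)c1`: > 50000 nM

Compound 1 `COc1ccc2c(c1)OC(c1cc(OC)c(OC)c(OC)c1)C(C(=O)Nc1ccccc1)=C2` and compound 2 `CNC(=O)C1=Cc2ccc(OC)cc2OC1c1cc(OC)c(OC)c(OC)c1` share one core and differ only in the group on the amide-type nitrogen. In a functional assay for inhibition of nuclear factor NF-kappa-B complex (Homo sapiens) (a lower number here means a stronger inhibitor, a higher number a weaker inhibitor), compound 1 gives 17500 nM. In this assay compound 2 reaches only a limit, > 50000 nM. The step of an at least 2.8-fold higher number from compound 1 to compound 2 (0.45 log units; beyond the scatter) therefore shows a weakening, though because of the limit of > 50000 nM in this assay, at which 1 of the 2 values shown sits, its full size is not known. Compound 3 `COc1ccc2c(c1)OC(c1cc(OC)c(OC)c(OC)c1)C(C(N)=O)=C2` takes the same direction one stage further: hydrogen in place of methyl on an amide-type nitrogen. Going by the values given here, only that one measured step bears on this change, and it ran toward weaker inhibition as the group on the nitrogen shrank. The same direction, or no step beyond the scatter, is expected from compound 2 to compound 3, a step that the limit leaves unreadable from compound 2 to compound 3. Compound 3 is therefore expected to give about 80000 nM in this assay, with a range from 30000 nM to 250000 nM, most likely again reported only as a limit.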

Compound 3, half-maximal inhibitory concentration: > 50000 nM
Compound 3 gave a limit, no number; the forecaster's own chance of this, stated with the estimate: 85%; the middle value lies beyond the limit too.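

Replacing the phenyl on the amide-type nitrogen outright with hydrogen gives, in this assay, an at least 2.8-fold higher number from compound 1 to compound 3 (0.45 log units; beyond the scatter), so methyl and hydrogen at this position both now give weaker inhibition than phenyl. Compound 3, like compound 2, is recorded only as a limit, which leaves compound 1 as the only one of the three with an actual number. The step from methyl to hydrogen cannot be read, and the full size of both losses from phenyl stays unknown because of this: the limit of > 50000 nM in this assay, at which 2 of the 3 values shown sit.

From the compounds shown here alone, whether a benzyl group, a cyclohexyl ring or a longer chain such as butyl on this nitrogen would match compound 1 remains open. So does whether a phenyl ring carrying a methoxy group or a chlorine atom would move the value in either direction.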